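Spiro-piperidine amides: hydroxybutyl amide versus piperidine amide

A few compounds are considered here, and "the series" means these few. Any claim that something is new, unique, unknown or untested is made for them only; others in the source may bear on it.

Measured so far:
- compound 1, `O=C(CN1CN(c2ccccc2)C2(CCN(C(=O)c3ccc(C4CCCCC4)cc3)CC2)C1=O)NCCCCO`: 10300 nM
- compound 2, `CC(C)(C)c1ccc(C(=O)N2CCC3(CC2)C(=O)N(CC(=O)NCCCCO)CN3c2ccccc2)cc1`: 19200 nM
- compound 3, `CCc1nn(CC)c(C2CCN(C(=O)CN3CN(c4ccccc4)C4(CCN(C(=O)c5ccc(C(C)(C)C)cc5)CC4)C3=O)CC2)c1C`: 2500 nM

All three numbers come from an assay on HEK293 cells for displacement of a labelled ligand from NPC1-like intracellular cholesterol transporter 1 (Homo sapiens); a higher number here means a weaker inhibitor, a lower number a stronger inhibitor. Compound 1 stands second highest of the three. Its nearest neighbour is compound 2, with a 1.9-fold higher number from compound 1 to compound 2 (0.27 log units; within the scatter), a step within the scatter, so no order is read between these two. Among the compounds with values here, compound 3 lies furthest from compound 1, its number a good deal lower and beyond the scatter, but compound 3 differs from compound 1 in more than one place, so no single step is drawn from that pair.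

Compound 4, `O=C(CN1CN(c2ccccc2)C2(CCN(C(=O)c3ccc(C4CCCCC4)cc3)CC2)C1=O)N1CCCCC1`, is not yet measured in this assay. It differs from compound 1 as follows: piperidin-1-yl in place of (4-hydroxybutyl)amino on a carbonyl carbon. Within the data shown here, no measured step bears on this change: the one step recorded, from compound 1 to compound 2, concerns the aromatic substituent and was within the scatter. The data therefore give no direction for this amide change, and no step beyond the scatter is expected.

For compound 4 the estimate is 9000 nM, ranging from 3000 nM to 30000 nM, which means an expected step of a 1.1-fold lower number from compound 1 to compound 4 (0.06 log units; within the scatter).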

Compound 4, half-maximal inhibitory concentration: 1100 nM
The estimate for compound 4 lay 8.2-fold (0.91 log units) above the measured number; the measured number lies below the stated range.
By their numbers in this assay, from the lowest: compound 4; then compound 3; then compounds 1 and 2 (each within the scatter of the next).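

In this assay, within the data shown here, the amide on the carbonyl carbon whose other neighbour is a saturated chain carbon emerges as a place where a single change can move the number: piperidin-1-yl in place of (4-hydroxybutyl)amino gives a 9.4-fold lower number from compound 1 to compound 4 (0.97 log units; beyond the scatter), while the only earlier one-place step, tert-butyl in place of cyclohexyl on an aromatic carbon, gave a 1.9-fold higher number from compound 1 to compound 2 (0.27 log units; within the scatter). Both groups have 6 heavy atoms, so the step does not come with a change in that count; it does combine three other differences, namely an open chain giving way to a six-membered non-aromatic ring, the loss of the oxygen, and a drop from 2 hydrogen-bond donors to 0. No measurement shown here explains the step.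

The compounds shown do not separate these three differences: butylamino would keep the open chain without the hydroxyl, and 4-hydroxypiperidin-1-yl would keep the ring with it. Going by these compounds, it also remains open whether unsubstituted piperidin-1-yl gives a step of similar size when the aromatic substituent is tert-butyl rather than cyclohexyl.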